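This account rests on a few compounds, and the source may have more. Where it says the series, first, only, none or still open, it means among the compounds named here.

Of the compounds shown here, two sharing one core have been measured in a functional assay on HCT-116 cells (Homo sapiens) for antiproliferative activity, read by MTT assay, with a stated time of 48 h; on this read-out higher numbers stand for weaker inhibition and lower numbers for stronger inhibition. Compound 1, `N#CC1=C(N)Oc2c(c3nc4ccccc4nc3c3ccccc23)C12C(=O)N(Cc1cnnn1-c1ccccc1Cl)c1ccccc12`, gives only a limit of the assay in this assay: for compound 1 the read-out is > 50000 nM. Compound 2, `N#CC1=C(N)Oc2c(N)cc3nc4ccccc4nc3c2C12C(=O)N(Cc1cnnn1-c1cccc(Br)c1)c1ccccc12`, carries a 3-bromophenyl on an aromatic nitrogen and gives 26100 nM in this assay. Compound 2 thus holds the only number shown; the one further value belongs to compound 1 and is a limit, as recorded in the limit of > 50000 nM in this assay, at which 1 of the 2 values shown sits. Among the compounds with values here, because this is a limit and not a number, no step between compound 1 and compound 2 can be counted.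

Compound 3, `N#CC1=C(N)Oc2c(N)cc3nc4ccccc4nc3c2C12C(=O)N(Cc1cnnn1-c1cc(Cl)ccc1Cl)c1ccccc12`, differs from compound 2 in one place: 2,5-dichlorophenyl in place of 3-bromophenyl on an aromatic nitrogen. Within the data shown here, no measured step of this kind is available for comparison, so the expectation rests on compound 2 alone. With one halogenated phenyl giving way to another halogenated phenyl on the same aromatic nitrogen, the step from compound 2 to compound 3 in this assay is expected to be a 1.1-fold higher number from compound 2 to compound 3 (0.06 log units; within the scatter), not beyond the usual scatter. Compound 3 is therefore expected to give about 30000 nM in this assay, within a range from 10000 nM to 90000 nM.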

Compound 3, half-maximal inhibitory concentration: > 50000 nM
Compound 3: no number, only a limit; the forecaster's own chance of this, stated with the estimate: 30%; middle value at least 1.6-fold (0.22 log units) away from the limit.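

Within the data shown here, this is the first step that can be read at this position, on the aromatic nitrogen, and in this assay replacing 3-bromophenyl with 2,5-dichlorophenyl gives an at least 1.9-fold higher number from compound 2 to compound 3 (0.28 log units; that floor lies within the scatter) as its result. That step rests on a limit of the assay for compound 3, so it marks only a floor: the true gap may be larger, but what can be read does not go beyond the usual scatter, and the swap brings no sign of stronger inhibition. Among these compounds, compound 2 now stands as the only compound with an actual number, and limits make up most of the picture: the limit of > 50000 nM in this assay, at which 2 of the 3 values shown sit.

Steps involving compound 1 cannot be read, since it differs from the others in more than one place and also gives only a limit. The compounds shown leave open whether a different group on this aromatic nitrogen, such as an unsubstituted phenyl, a methoxyphenyl or an aminophenyl, would give a lower number than compound 2 does, and whether halogens at other places on the phenyl would change the result.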